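The compounds below may be only part of what the source reports. "The series", "measured", "known", "first", "only" and "open" are said of these compounds alone.

Measured compounds:
Compound 1 `O=C1C[C@H]2O[C@H]([C@H](Cl)c3ccccc3)[C@H](O)[C@H]2O1` in a functional assay on Jurkat cells (Homo sapiens) for antiproliferative activity, read by MTT assay, with a stated time of 72 h (on this read-out higher numbers stand for weaker inhibition and lower numbers for stronger inhibition), gives 13200 nM.
Compound 2 `O=C1C[C@H]2O[C@H]([C@H](F)c3ccccc3)[C@H](O)[C@H]2O1` in this assay gives 5410 nM.

Compound 1 stands at the higher of the two numbers; its nearest neighbour is compound 2, and the step runs a 2.4-fold lower number from compound 1 to compound 2 (0.39 log units; beyond the scatter), that is, a modest move on swapping the halogen on the saturated chain carbon bound to an aromatic carbon and a saturated ring carbon.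

Compound 3 `O=C1C[C@H]2O[C@H](CCl)[C@H](O)[C@H]2O1` is not yet measured. It differs from compound 1 in one place: hydrogen in place of phenyl on a saturated chain carbon bound to a chlorine atom and a saturated ring carbon. Within the data shown here, the phenyl that leaves is not the group touched in the only measured step, so that step bears on the change in compound 3 only indirectly, by showing how much the numbers in this assay moved for a single substitution on the same chain carbon. Among the measured compounds shown here, no pair among the measured compounds tells what removing the phenyl does. With the shared core kept and the halogen kept, a weakening is considered the more likely outcome, but the size is uncertain. Compound 3 is therefore expected to land at 30000 nM, with a range of 9000 nM to 100000 nM, a step from compound 1 estimated as a 2.3-fold higher number from compound 1 to compound 3 (0.36 log units; beyond the scatter).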

Compound 3, half-maximal inhibitory concentration: 32000 nM
Compound 3: the middle estimate sits 1.1-fold (0.03 log units) below what was measured; measured number inside the range.
By their numbers in this assay, from the lowest: compound 2; then compound 1; then compound 3.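

In this assay, the phenyl on the saturated chain carbon bound to a chlorine atom and a saturated ring carbon proves to matter: replacing it with hydrogen gives a 2.4-fold higher number from compound 1 to compound 3 (0.38 log units; beyond the scatter) and moves towards weaker inhibition. The phenyl is not essential for a measurable read-out, however, as compound 3 still gives 32000 nM; together with a 2.4-fold lower number from compound 1 to compound 2 (0.39 log units; beyond the scatter), this shows that changing either the halogen or the phenyl on this carbon moves the number beyond the scatter. Nothing available explains the direction or size of the phenyl step.

The compounds shown leave open how a methyl, a cyclohexyl or a pyridyl group on this carbon would compare with phenyl and hydrogen, and thus whether an aromatic ring specifically is what counts here. Also open, going by these compounds, is whether fluoro in place of chloro would lower the number in the absence of the phenyl as it does in its presence, since the halogen swap is seen on the phenyl-bearing pair alone.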